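Hydroxamic acid series: chloro removal on the shared core

The source may hold more compounds than are shown below. What is called first, only, known or untested is meant among the compounds shown, and "the series" means these compounds.

Measured so far in a functional assay on MGC-803 cells (Homo sapiens) for antiproliferative activity, read by MTT assay, with a stated time of 72 h; on this read-out lower numbers stand for stronger inhibition and higher numbers for weaker inhibition:
compound 1, `O=C(NO)c1ccc(NCc2nc(-c3cccs3)nn2-c2ccc(O)cc2)cc1`: > 20000 nM (a limit)
compound 2, `COc1ccc(-n2nc(-c3ccccc3)nc2CNc2ccc(C(=O)NO)cc2)cc1`: 7050 nM
compound 3, `O=C(NO)c1ccc(NCc2nc(-c3ccccc3Cl)nn2-c2ccccc2)cc1`: > 20000 nM (a limit)

Compound 3 sits at the limit of this assay; its value is not a number. Compound 1 sits at that same limit, so the limit of > 20000 nM in this assay, at which 2 of the 3 values shown sit, holds for two of the three values shown. Within the data shown here, compound 2 is the only member with a measured number.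

Compound 4, `O=C(NO)c1ccc(NCc2nc(-c3ccccc3)nn2-c2ccccc2)cc1`, is to be measured. It differs from compound 3 by hydrogen in place of chloro on an aromatic carbon. Among the measured compounds shown here, no step between measured compounds is available, so a starting point is lacking. A modest gain is expected, within or just beyond the scatter: an at least 1.6-fold lower number from compound 3 to compound 4 (0.22 log units; that floor lies within the scatter). Compound 4 is therefore estimated at 12000 nM, between 3500 nM and 30000 nM.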

Compound 4, half-maximal inhibitory concentration: 17700 nM
Beside the measured number, compound 4's estimate is 1.5-fold (0.17 log units) below it; the measured number falls inside the stated range.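

Going from 2-chlorophenyl to phenyl gives an at least 1.1-fold lower number from compound 3 to compound 4 (0.05 log units; that floor lies within the scatter), so no gain from losing the chloro can be claimed. That step stays a floor, as compound 3 is held at a limit: the limit of > 20000 nM in this assay, at which 2 of the 4 values shown sit. Hydrogen in place of methoxy on an aromatic carbon gives a 2.5-fold higher number from compound 2 to compound 4 (0.40 log units; beyond the scatter), the only step here with both ends measured, so the methoxy change registers where the chloro change does not.

Still open, on these data alone, is how an amine or a carboxylic acid in place of the chloro would read. Also open, as far as these compounds go, is whether a fluoro group there would differ from hydrogen.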